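This account rests on a few compounds, and the source may have more. Where it says the series, first, only, none or still open, it means among the compounds named here.

Values in a functional assay on MM1.S cells (Homo sapiens) for inhibition, with a stated time of 72 h (on this read-out lower numbers stand for stronger inhibition and higher numbers for weaker inhibition), so far:

compound 1 `O=C(NO)c1ccc2c(c1)CCN(S(=O)(=O)c1cc(F)c(F)c(F)c1F)C2`: 1540 nM
compound 2 `CC(C)N(Cc1ccc(C(=O)NO)cc1)Cc1cc(F)c(F)c(F)c1F`: 11400 nM
compound 3 `CC(C)CN(Cc1ccc(C(=O)NO)cc1)S(=O)(=O)c1cc(F)c(F)c(F)c1F`: 690 nM

Compound 3 stands lowest of the three numbers in this assay. Compound 1 gives a higher number than compound 3, beyond the scatter, and compound 2 gives the highest number of the set, far beyond the scatter. Going by the values given here, no single-change pair among the measured compounds is available, so the size of steps is not yet calibrated.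

Compound 4 `COCCN(Cc1ccc(C(=O)NO)cc1)S(=O)(=O)c1cc(F)c(F)c(F)c1F` differs from compound 3 in one place: methoxymethyl in place of isopropyl on a saturated chain carbon bound to a sulfonamide nitrogen. With nothing measured on this kind of change, compound 4 is expected to stay close to compound 3, with a step of a 1.4-fold higher number from compound 3 to compound 4 (0.14 log units; within the scatter) of modest size in this assay, if anything toward a higher number. Compound 4 is estimated at 950 nM, within 350 nM to 2500 nM.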

Compound 4, half-maximal inhibitory concentration: 710 nM
Compound 4: middle estimate off by 1.3-fold (0.13 log units), on the high side, within the range that was stated.
By their numbers in this assay, from the lowest: compounds 3 and 4 (each within the scatter of the next); then compound 1; then compound 2.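

In this assay, the step of a 1.0-fold higher number from compound 3 to compound 4 (0.01 log units; within the scatter) gives the series its first single-change calibration, and it lies within the scatter. On a saturated chain carbon bound to a sulfonamide nitrogen, methoxymethyl and isopropyl therefore read alike, even though methoxymethyl carries a hydrogen-bond acceptor and isopropyl carries none. No measurement at hand offers an explanation for this.

From the compounds shown here alone, whether an amine, a carboxylic acid or a longer chain at this place would also stay within the scatter of compound 3 remains open.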